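The compounds below may be only part of what the source reports. "The series", "measured", "known", "first", "only" and "open" are said of these compounds alone.

For the measured compounds named here, in an assay on isolated protein (strain Sprague-Dawley) for inhibition of Amine oxidase [flavin-containing] B (Rattus norvegicus), read by spectrophotometry, with a stated time of 5 min (on this read-out higher numbers stand for weaker inhibition and lower numbers for stronger inhibition), compound 2 `CN(C)C(=O)COc1cc(=O)oc2cc(OCc3cccc(Cl)c3)ccc12` gives 501 nM, the lowest of the two numbers measured so far; its nearest neighbour is compound 1 `CC(C)Oc1cc(=O)oc2cc(OCc3cccc(Cl)c3)ccc12`, which gives 24500 nM. Going by the values given here, the one step measured between them, a 49-fold lower number from compound 1 to compound 2 (1.69 log units; beyond the scatter), replaced isopropyl with (dimethylcarbamoyl)methyl on the same ring oxygen.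

Compound 3 `CCNc1cc(=O)oc2cc(OCc3cccc(Cl)c3)ccc12` has not yet been measured. It differs from compound 2 by ethylamino in place of (dimethylcarbamoyl)methoxy on an aromatic carbon. Among the compounds with values here, the only step that bears on this position is a 49-fold lower number from compound 1 to compound 2 (1.69 log units; beyond the scatter), and it shows that the group here moves the number strongly. Compound 3 lacks the (dimethylcarbamoyl)methoxy that distinguished compound 2 from compound 1 and carries a small group instead, so a step upward, partly back toward the number of compound 1, is expected, though its size is uncertain because no ethylamino has been measured in this series. For compound 3 the expected step is a 16-fold higher number from compound 2 to compound 3 (1.20 log units; beyond the scatter). The estimate for compound 3 is 8000 nM, with a range from 1500 nM to 40000 nM.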

Compound 3, half-maximal inhibitory concentration: 28.2 nM
Beside the measured number, compound 3's estimate is 280-fold (2.45 log units) above it, outside the stated range (below it).
By their numbers in this assay, from the lowest: compound 3; then compound 2; then compound 1.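

In this assay, the lower number at this position does not depend on keeping (dimethylcarbamoyl)methoxy: the smaller ethylamino group, which adds a hydrogen-bond donor, gives an 18-fold lower number from compound 2 to compound 3 (1.25 log units; beyond the scatter). For the compounds shown here, replacing isopropoxy with ethylamino gives an 870-fold lower number from compound 1 to compound 3 (2.94 log units; beyond the scatter), so the position spans a much wider range than the earlier pair showed, and the atom joined to the aromatic carbon changes from oxygen to nitrogen for the first time. No supporting measurement accounts for these steps.

The compounds shown leave open whether the step follows the nitrogen link, its hydrogen or the ethyl chain. Ethoxy and dimethylamino at this position would separate these, while propylamino would show how a longer chain on the nitrogen reads.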